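The compounds below may be only part of what the source reports. "The series", "measured", "known", "first", "only" and "open" are said of these compounds alone.

Compound 1 `O=C1/C(=C/c2ccccc2)CCC/C1=C\c1ccc(O)cc1` is the reference point of this small set. In an assay on isolated protein for inhibition of Alpha glucosidase (Homo sapiens), with stated times of 5 min and 15 min, tested at 50 uM (on this read-out higher numbers stand for more inhibition at the one concentration tested (going by the name of the read-out) and lower numbers for less inhibition), compound 1 gives 53%, the highest of the three numbers measured. Compound 2 `O=C1/C(=C/c2ccccc2)CCC/C1=C\c1ccc(Br)cc1` gives 29.1% in this assay, and compound 3 `Cc1ccc(/C=C2\CCC/C(=C\c3ccccc3)C2=O)cc1` gives 34.1%. The two measured steps away from compound 1 both remove the hydroxy group: a number 23.9 percentage points lower from compound 1 to compound 2 (beyond the scatter), and a number 18.9 percentage points lower from compound 1 to compound 3 (beyond the scatter). Between the two replacements the difference is small, a number 5 percentage points higher from compound 2 to compound 3 (within the scatter).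

Compound 4 `O=C1/C(=C/c2ccccc2)CCC/C1=C\c1ccc(O)c(O)c1` has not yet been measured. It differs from compound 1 by hydroxy in place of hydrogen on an aromatic carbon. Going by the values given here, no measured step adds a hydroxy group, so the expectation rests on the two steps in which the hydroxy of compound 1 was taken away, each costing a modest amount of inhibition. A second hydroxy is therefore expected to leave the number unchanged within the scatter or to lift it modestly; a fall beyond the scatter is not expected. Compound 4 is estimated at 60%, with a range from 45% to 76%, meaning an expected step of a number 7 percentage points higher from compound 1 to compound 4 (within the scatter).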

Compound 4, a percentage reported as inhibition, at one concentration (the size of the read-out at that concentration, not a potency): 90.7%
Beside the measured number, compound 4's estimate is 30.7 percentage points below it; measured number above the stated range.
By their numbers in this assay, from the lowest: compounds 2 and 3 (each within the scatter of the next); then compound 1; then compound 4.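

In this assay, hydroxy in place of hydrogen on an aromatic carbon, ortho to a hydroxy group, gives a number 37.7 percentage points higher from compound 1 to compound 4 (beyond the scatter). The earlier compounds shown here showed only what was lost when the hydroxy of compound 1 was replaced by bromo or methyl; this step shows that inhibition can still rise through a change on that same ring, and by more than either replacement cost. Nothing given here explains the rise.

On these data alone, whether the gain needs a hydroxy group in particular stays open: a methoxy group or an amine in the same place would test that. Also open, as far as these compounds go, is whether the added hydroxy would bring a similar gain without the hydroxy already present in compound 1, and how the gain would appear as a potency rather than at one concentration.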